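Benzofuranylmethyl in place of oxanylmethyl on the shared core

The source may report more compounds than this note shows. Statements on the series, on what has been measured and on what is new or still open speak of the compounds shown alone.

Of the compounds shown here, three have so far been measured in a physicochemical assay for lipophilicity, at pH 7.4; a higher number here means a more lipophilic compound, a lower number a more polar compound. Compound 1 `CNC(=O)c1cc(C(=O)NC2CCC2)cn(Cc2cccnc2)c1=O` gives 1.8 there. Compound 2 `CNC(=O)c1cc(C(=O)NC2CC2)cn(CC2CCOCC2)c1=O` gives 1.5, the lowest of the three numbers; the nearest to it is compound 1, whose number sits within the scatter of it, and the furthest is compound 3 `CNC(=O)c1cc(C(=O)NCCC(C)C)cn(Cc2ccccc2)c1=O`, which in this assay gives 4.8, a gap well beyond the scatter. For the measured compounds named here, no two of the measured compounds differ in a single place, so no measured step exists to lean on.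

Compound 4 `CNC(=O)c1cc(C(=O)NC2CC2)cn(Cc2cccc3occc23)c1=O` is not yet measured. It differs from compound 2 in one place: 1-benzofuran-4-yl in place of oxan-4-yl on a saturated chain carbon bound to an aromatic nitrogen. The step of a number 1.80 log units higher from compound 2 to compound 4 (beyond the scatter) is expected to be large and upward. Going by the values given here, that expectation rests on compound 3, the only measured member carrying an aromatic ring at that carbon without a ring nitrogen, since in this assay compound 3 gives 4.8. For compound 4 the estimate is 3.3, with a range from 2.6 to 4.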

Compound 4, distribution coefficient: 3.4
Compound 4: middle estimate off by 0.10 log units, on the low side, and the stated range covers the measured number.
By their numbers in this assay, from the lowest: compounds 2 and 1 (each within the scatter of the next); then compound 4; then compound 3.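

In this assay this position now has a measured single-place change: with 1-benzofuran-4-yl in place of oxan-4-yl on a saturated chain carbon bound to an aromatic nitrogen, the series shows a number 1.90 log units higher from compound 2 to compound 4 (beyond the scatter) while the rest of compound 2 stays fixed. The change therefore moves the read-out by a large amount, although the groups have the same counts of hydrogen-bond donors and acceptors and neither carries a net charge. Nothing available explains the size of this step.

As far as these compounds go, whether a carboxylic acid or a primary amine at this position would take the number in the opposite direction from oxan-4-yl remains open. Also open, from the compounds shown here alone, is whether the step keeps its size when the cyclopropyl amide on the shared core is replaced.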